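Swapping an isopropoxy for an arylamino on the shared core

The source may hold more compounds than are shown below. What is called first, only, known or untested is meant among the compounds shown, and "the series" means these compounds.

Compound 2 `CC(C)OC1=C(C(=O)c2ccccc2)C(c2ccc(Br)cc2)N(CCCn2ccnc2)C1=O` gives 18900 nM in a functional assay on NCI-H1299 cells (Homo sapiens) for antiproliferative activity, read by MTT assay, with a stated time of 72 h (on this read-out higher numbers stand for weaker inhibition and lower numbers for stronger inhibition), the smallest of the three numbers shown, but compound 1 `CCOC1=C(C(=O)c2ccccc2)C(c2ccc(Br)cc2)N(CCCn2ccnc2)C1=O` with 28900 nM differs from it only within the scatter, as a 1.5-fold lower number from compound 1 to compound 2 (0.18 log units; within the scatter) shows. Compound 3 `NC1=C(C(=O)c2ccccc2)C(c2ccc(Br)cc2)N(CCCn2ccnc2)C1=O` gives 169000 nM in this assay. Compound 4 `CCOc1ccc(NC2=C(C(=O)c3ccccc3)C(c3ccc(Br)cc3)N(CCCn3ccnc3)C2=O)cc1` differs from compound 2 by (4-ethoxyphenyl)amino in place of isopropoxy on a double-bonded ring carbon. For the measured compounds named here, the steps that bear on this change replace the alkoxy with a bare amino: an 8.9-fold higher number from compound 2 to compound 3 (0.95 log units; beyond the scatter) and a 5.8-fold higher number from compound 1 to compound 3 (0.77 log units; beyond the scatter), both modest and beyond the scatter. Going by the values given here, no measured step covers an arylamino, so the expectation is loose. A somewhat higher number is expected for compound 4, 35000 nM with a range from 9000 nM to 130000 nM. The step of a 1.9-fold higher number from compound 2 to compound 4 (0.27 log units; within the scatter) this implies is expected to be modest.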

Compound 4, half-maximal inhibitory concentration: 20000 nM
Compound 4: the middle estimate sits 1.8-fold (0.24 log units) above what was measured; measured number inside the range.
By their numbers in this assay, from the lowest: compounds 2, 4 and 1 (each within the scatter of the next); then compound 3.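

On this double-bonded ring carbon, the larger (4-ethoxyphenyl)amino group is tolerated as well as either alkoxy group in this assay, with a 1.1-fold higher number from compound 2 to compound 4 (0.02 log units; within the scatter) and a 1.4-fold lower number from compound 1 to compound 4 (0.16 log units; within the scatter). Adding the 4-ethoxyphenyl to the bare amino nitrogen gives an 8.5-fold lower number from compound 3 to compound 4 (0.93 log units; beyond the scatter), so the weak result of compound 3 does not extend to every group attached through nitrogen. No evidence is available to explain these steps. On these data alone, it remains open whether the aromatic ring or its ethoxy matters more. A plain phenylamino or a methylamino group at this position would help separate them.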